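Trifluoromethyl in place of fluoro: an expected cytotoxicity step

The source may hold more compounds than are shown below. What is called first, only, known or untested is meant among the compounds shown, and "the series" means these compounds.

Of the compounds shown here, three sharing one core have been tested in an ADME assay on HEK293 cells (Homo sapiens) for cytotoxicity, read by sulforhodamine B assay, with a stated time of 48 h, tested at 10 uM; a higher number here means more inhibition at the concentration tested (going by the name of the read-out), a lower number less inhibition. Compound 1 `CCCCCCc1cn(C(c2ccccc2)c2cc3cc(Br)ccc3nc2OC)nn1` gives -3.17%. Compound 2 `COc1nc2ccc(Br)cc2cc1C(c1ccccc1)n1cc(-c2ccccc2F)nn1` gives 3.97%, and compound 3 `COc1nc2ccc(Br)cc2cc1C(c1ccccc1)n1cc(CCO)nn1` gives 4.54%. Among the measured compounds shown here, the three numbers lie close together: a number 7.1 percentage points higher from compound 1 to compound 2 (within the scatter), a number 7.7 percentage points higher from compound 1 to compound 3 (within the scatter) and a number 0.6 percentage points higher from compound 2 to compound 3 (within the scatter) are each within the scatter, so no compound can be placed above or below another. Compound 2 therefore stands among three readings that, for practical purposes, agree.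

Compound 4 `COc1nc2ccc(Br)cc2cc1C(c1ccccc1)n1cc(-c2ccccc2C(F)(F)F)nn1` differs from compound 2 by one change: trifluoromethyl in place of fluoro on an aromatic carbon. For the measured compounds named here, no measured step alters exactly this group, so the nearest guides are the two steps that exchange the group on an aromatic carbon of the shared core, from compound 1 to compound 2 and from compound 2 to compound 3, and both stayed within the scatter. Nothing in these data points to a move beyond the scatter, so compound 4 is expected to sit close to compound 2, with a number 0 percentage points higher from compound 2 to compound 4 (within the scatter) expected to be small. The estimate for compound 4 is 4%, ranging from -8% to 16%.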

Compound 4, a percentage reported as inhibition, at one concentration (the size of the read-out at that concentration, not a potency): 14.3%
Compound 4: the middle estimate sits 10.3 percentage points below what was measured; low and high end bracket the measured number.
By their numbers in this assay, from the lowest: compounds 1, 2, 3 and 4 (each within the scatter of the next, the first and the last beyond it).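

Fluoro and trifluoromethyl, on an aromatic carbon of a six-membered aromatic ring of carbon only and ortho to a large group, are not interchangeable in this assay: this one change gives a number 10.3 percentage points higher from compound 2 to compound 4 (beyond the scatter), a modest step that clears the scatter. Replacing the whole substituent gives a number 17.5 percentage points higher from compound 1 to compound 4 (beyond the scatter), while a number 9.8 percentage points higher from compound 3 to compound 4 (within the scatter), so compound 4 stands apart from compound 1 and compound 2 but not from compound 3. No supporting data are available to explain why this change moves the reading.

From the compounds shown here alone, it remains open whether chloro, methyl or methoxy in the same place would give a reading nearer compound 2 or compound 4. With one concentration per compound, these readings also leave open how the effect of compound 4 would change with concentration.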